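A Bromophenyl Swap on the Shared Core

This account rests on a few compounds, and the source may have more. Where it says the series, first, only, none or still open, it means among the compounds named here.

Compound 1 `FC(F)(F)c1cc(NC[C@H]2CCCCN2)c2cn[nH]c2c1` gives 19% in an assay for inhibition of Indoleamine 2,3-dioxygenase 1 (Homo sapiens), with stated times of 10 min and 60 min, tested at 10 uM; a lower number here means a weaker effect, a higher number a stronger effect of the compound at the concentration tested
Compound 2 `O=[N+](O)c1c(Cl)cccc1CNc1cc(C(F)(F)F)cc2[nH]ncc12` gives 45% in this assay
Compound 3 `N#Cc1cc(NCc2ccccc2[N+](=O)[O-])c2cn[nH]c2c1` gives 7% in this assay

Compound 1 stands second highest of the three numbers in this assay: compound 3 lies lower, beyond the scatter, and compound 2 lies higher, also beyond the scatter. Compound 4 `FC(F)(F)c1cc(NCc2cccc(Br)c2)c2cn[nH]c2c1` has not been measured. It differs from compound 1 as follows: 3-bromophenyl in place of piperidin-2-yl on a saturated chain carbon bound to a nitrogen on an aromatic ring. Among the compounds with values here, no step between measured compounds isolates this change, so the expectation rests on the spread of the three values alone. A moderate upward step is expected, a number 11 percentage points higher from compound 1 to compound 4 (beyond the scatter), though it may fall within the scatter. Compound 4 is estimated at 30%, ranging from 10% to 55%.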

Compound 4, a percentage reported as inhibition, at one concentration (the size of the read-out at that concentration, not a potency): 23%
Estimate against measurement, compound 4: 7 percentage points above, within the range that was stated.
By their numbers in this assay, from the lowest: compound 3; then compounds 1 and 4 (each within the scatter of the next); then compound 2.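

In this assay, 3-bromophenyl in place of piperidin-2-yl on a saturated chain carbon bound to a nitrogen on an aromatic ring gives a number 4 percentage points higher from compound 1 to compound 4 (within the scatter). Within the data shown here, this is the first single-place comparison, and it shows that a six-membered aromatic ring of carbon only and a six-membered non-aromatic ring with a hetero atom can stand at this place without a difference beyond the scatter. Nothing shown explains why the two numbers lie so close.

The compounds shown leave open how an unsubstituted phenyl, a carboxylic acid or a longer chain at this place would read. They also leave open whether the bromine contributes at all.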